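The source may hold more compounds than are shown below. What is called first, only, known or untested is meant among the compounds shown, and "the series" means these compounds.

Measured compounds in a functional assay on MIA PaCa-2 cells (Homo sapiens) for inhibition, read by MTT assay, with a stated time of 3 days; on this read-out higher numbers stand for weaker inhibition and lower numbers for stronger inhibition:

Compound 1, `CCN(CC)S(=O)(=O)c1ccc(S(=O)(=O)N2CCC[C@@H](C(=O)N(C)C(C)C)C2)cc1`, gives > 10000 nM, which is a limit of the assay and not a number.
Compound 2, `CCN(CC)S(=O)(=O)c1ccc(S(=O)(=O)N2CCC[C@@H](C(=O)N3CCN(c4nc(C)no4)CC3)C2)cc1`, gives > 10000 nM, again a limit rather than a number.
Compound 3, `CCN(CC)C(=O)[C@@H]1CCCN(S(=O)(=O)c2ccc(S(=O)(=O)N(CC)CC)cc2)C1`, gives > 10000 nM, also a limit.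

All three compounds share one core and differ only in the group on the carbonyl carbon. Because every value sits at the limit of > 10000 nM in this assay, at which 3 of the 3 values shown sit, none of the steps among them can be read: a step that the two limits leave unreadable from compound 1 to compound 2, a step that the two limits leave unreadable from compound 1 to compound 3 and a step that the two limits leave unreadable from compound 2 to compound 3 all remain of unknown size. Compound 2 therefore stands nowhere in particular on the numbers shown; it is simply one of three compounds for which this assay reports only a limit.

Compound 4, `CCN(CC)S(=O)(=O)c1ccc(S(=O)(=O)N2CCC[C@@H](C(=O)N3CCN(c4nc(C(F)(F)F)no4)CC3)C2)cc1`, differs from compound 2 in one place: trifluoromethyl in place of methyl on an aromatic carbon. Within the data shown here, no measured step involves a trifluoromethyl group, so nothing in the data speaks for a large change in either direction. The step from compound 2 to compound 4 is expected to be a step that the limit leaves unreadable from compound 2 to compound 4, and most likely the assay will again report only a limit. Compound 4 is estimated at 15000 nM, with a range from 3000 nM to 60000 nM.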

Compound 4, half-maximal inhibitory concentration: > 10000 nM
Compound 4: only a limit was reported (the forecaster's own chance of this, stated with the estimate: 75%); the middle value lies beyond the limit too.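

In this assay compound 4 gives > 10000 nM, which is a limit and not a number. The step between compound 2 and compound 4 therefore cannot be read, as both carry only a limit: the limit of > 10000 nM in this assay, at which 4 of the 4 values shown sit.

The compounds shown leave open how far past this limit each one lies, and whether methyl or trifluoromethyl makes any difference in this assay.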